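Hydroxy for methoxy on the dimethylamino-aryl pyrazole

The compounds below may be only part of what the source reports. "The series", "measured", "known", "first", "only" and "open" are said of these compounds alone.

Working notes on the pyrazole series. Two members are measured in a functional assay on SN12C cells (Homo sapiens) for inhibition, read by sulforhodamine B assay, with a stated time of 48 h; on this read-out higher numbers stand for lower toxicity in this test and lower numbers for higher toxicity in this test. Compound 1 `Cc1cc(O)cc(-c2nn(CC#N)cc2-c2ccnc(-c3ccc(Oc4ccccc4)cc3)c2)c1`, which carries a hydroxy-methylphenyl and a phenoxyphenyl arm, gives 9010 nM. Compound 2 `COc1cc(C)cc(-c2nn(CC#N)cc2-c2ccnc(-c3ccc(N(C)C)cc3)c2)c1`, with a methoxy-methylphenyl and a dimethylaminophenyl arm, returns only a limit of the assay, > 100000 nM, so no number stands for it. Within the data shown here, compound 1 and compound 2 differ in two places, so their values show only that one is a number and one is a limit; the limit is where one of the two values sits (the limit of > 100000 nM in this assay, at which 1 of the 2 values shown sits). The next member, compound 3 `Cc1cc(O)cc(-c2nn(CC#N)cc2-c2ccnc(-c3ccc(N(C)C)cc3)c2)c1`, is not yet measured. It differs from compound 2 by hydrogen in place of methyl on an oxygen on an aromatic ring, while the dimethylaminophenyl arm is kept. Among the measured compounds shown here, no measured step isolates this change. Since compound 1 with the same hydroxy arm gives 9010 nM, the expected step from compound 2 to compound 3 is a move toward a measurable value. Because compound 2 sits at the limit of > 100000 nM in this assay, at which 1 of the 2 values shown sits, it is uncertain whether a number will be read for compound 3. The estimated shift is the step of an at least 1.6-fold lower number from compound 2 to compound 3 (0.22 log units; that floor lies within the scatter). Compound 3 is therefore estimated at 60000 nM, in the range 15000 nM to 200000 nM.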

Compound 3, concentration lethal to 50% of the cells: > 100000 nM
Compound 3 gave a limit, no number; the forecaster's own chance of this, stated with the estimate: 55%; at least 1.6-fold (0.22 log units) between middle value and limit.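

In this assay compound 3 also returns a limit of the assay, > 100000 nM, and not a number. The change from methoxy to hydroxy on the 3-methoxy-5-methylphenyl arm therefore cannot be read in size, and with the dimethylaminophenyl arm kept, the hydroxy group does not by itself bring the series onto a measurable value: the limit of > 100000 nM in this assay, at which 2 of the 3 values shown sit. Among these compounds, with the 3-hydroxy-5-methylphenyl arm now held constant, dimethylamino in place of phenoxy on an aromatic carbon gives an at least 11-fold higher number from compound 1 to compound 3 (1.04 log units; beyond the scatter), the first readable single-place step, and it places the difference on the phenoxyphenyl arm rather than on the hydroxy group.

Still open, as far as these compounds go, is whether methoxy and hydroxy read differently when the phenoxy group is kept, a comparison that would need a number on both sides in this assay. Also open, from the compounds shown here alone, is how far the step from phenoxy depends on dimethylamino itself, for which a different group on that aromatic carbon, such as a primary amine, a carboxylic acid or a longer alkoxy chain, would be informative.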